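This account rests on a few compounds, and the source may have more. Where it says the series, first, only, none or still open, it means among the compounds named here.

Compound 1 `COc1ccc(-c2nc3cc(-c4nc5cc(N6CCN(C)CC6)ccc5[nH]4)ccc3[nH]2)cc1` carries a 4-methylpiperazin-1-yl group on an aromatic carbon of the shared core, and in a functional assay on PC-3 cells (Homo sapiens) for cytotoxicity (on this read-out lower numbers stand for stronger inhibition and higher numbers for weaker inhibition), compound 1 gives 840 nM. Compound 2 `COc1ccc(-c2nc3cc(-c4nc5cc(CCCN(C)C)ccc5[nH]4)ccc3[nH]2)cc1` replaces that ring with an open 3-(dimethylamino)propyl chain, and in this assay compound 2 gives 28000 nM; the step of a 33-fold higher number from compound 1 to compound 2 (1.52 log units; beyond the scatter) is the only measured one, and it leaves compound 2 with the highest number of the two.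

Compound 3 `COc1ccc(-c2nc3cc(-c4nc5cc(CN(C)C)ccc5[nH]4)ccc3[nH]2)cc1` is the next step from compound 2: dimethylamino in place of 2-(dimethylamino)ethyl on a saturated chain carbon bound to an aromatic carbon, so the same basic amine now sits one carbon away from the core instead of three. Within the data shown here, the one measured step, from the ring to the open chain, was large, but it changed the kind of group, not the length of a chain, so it gives no direct precedent here. Nothing measured shows whether a shorter chain helps or hurts in this assay, so the expected step of a 1.4-fold lower number from compound 2 to compound 3 (0.15 log units; within the scatter) is small and its direction uncertain. Compound 3 is therefore estimated at 20000 nM in this assay, with a wide range from 5000 nM to 80000 nM.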

Compound 3, half-maximal inhibitory concentration: 52000 nM
Beside the measured number, compound 3's estimate is 2.6-fold (0.41 log units) below it; measured number inside the range.
By their numbers in this assay, from the lowest: compound 1; then compounds 2 and 3 (each within the scatter of the next).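

In this assay, the two open chains cannot be told apart: the step is a 1.9-fold higher number from compound 2 to compound 3 (0.27 log units; within the scatter), so 3-(dimethylamino)propyl and (dimethylamino)methyl give numbers that lie within the usual scatter of each other, and these two compounds show no effect of chain length at this position. The gap to the ring, by contrast, is seen a second time, with a 62-fold higher number from compound 1 to compound 3 (1.79 log units; beyond the scatter) standing alongside the earlier 33-fold higher number from compound 1 to compound 2 (1.52 log units; beyond the scatter), so the large difference from 4-methylpiperazin-1-yl holds for both open chains and compound 1 remains the most potent of the three. No measurement shown here explains why the ring and the open chains differ so much in this assay.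

Still open, from the compounds shown here alone, is whether the ring itself matters or the way the group joins the shared core, which a plain dimethylamino group placed directly on the aromatic carbon, or a 4-methylpiperazin-1-yl ring held on a single chain carbon, could help to separate. Going by these compounds, it is also open whether the methyl on the ring counts, or whether the number would hold with an unsubstituted piperazin-1-yl or a morpholin-4-yl ring in the same place.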